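From 2-(allyloxy)phenyl to 3-(allyloxy)phenyl: working notes

This account rests on a few compounds, and the source may have more. Where it says the series, first, only, none or still open, it means among the compounds named here.

Within the data shown here, in a functional assay on MCF7 cells (Homo sapiens) for inhibition, read by MTT assay, with a stated time of 72 h (on this read-out higher numbers stand for weaker inhibition of growth and lower numbers for stronger inhibition of growth), compound 3 `C=CCOc1ccccc1/C=C1\SC(=S)N(C2CC(=O)N(c3ccc(Cl)cc3)C2=O)C1=O` gives 80300 nM, the highest number so far and beyond the scatter from the other two. Those are compound 1 `O=C1CC(N2C(=O)/C(=C/C(Cl)=C/c3ccc([N+](=O)[O-])cc3)SC2=S)C(=O)N1c1ccc(Cl)cc1` at 7950 nM and compound 2 `O=C1CC(N2C(=O)/C(=C/C(Cl)=C/c3ccc([N+](=O)[O-])cc3)SC2=S)C(=O)N1c1ccc(O)cc1` at 4000 nM. Compound 4 `C=CCOc1cccc(/C=C2\SC(=S)N(C3CC(=O)N(c4ccc(Cl)cc4)C3=O)C2=O)c1` differs from compound 3 by 3-(allyloxy)phenyl in place of 2-(allyloxy)phenyl on a double-bonded chain carbon bound to a double-bonded ring carbon; the two have the same atoms, joined differently. Among the measured compounds shown here, the only measured step, a 2.0-fold lower number from compound 1 to compound 2 (0.30 log units; within the scatter), is hydroxy in place of chloro on an aromatic carbon, so it bears on this change only weakly. For the measured compounds named here, no measured step moves the allyloxy group, so no shift beyond the scatter is expected in this assay. The estimated step is a 1.6-fold lower number from compound 3 to compound 4 (0.21 log units; within the scatter). The expected value for compound 4 is 50000 nM, with an estimated range of 12000 nM to 130000 nM.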

Compound 4, concentration for 50% growth inhibition: 98000 nM
Beside the measured number, compound 4's estimate is 2.0-fold (0.29 log units) below it, and the stated range covers the measured number.
By their numbers in this assay, from the lowest: compounds 2 and 1 (each within the scatter of the next); then compounds 3 and 4 (each within the scatter of the next).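

In this assay the move of the allyloxy group gives a 1.2-fold higher number from compound 3 to compound 4 (0.09 log units; within the scatter) and so stays within the scatter. This first step at this position shows that 3-(allyloxy)phenyl and 2-(allyloxy)phenyl on a double-bonded chain carbon bound to a double-bonded ring carbon cannot be told apart on this read-out. No supporting data are available to explain this result. On these data alone, whether an amine or a carboxylic acid in place of the allyloxy group would shift the number beyond the scatter remains open. Compounds 1 and 2 differ from this pair in more than one place, so that gap stays unassigned.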